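From compound 3 to compound 4: a new side chain

A few compounds are considered here, and "the series" means these few. Any claim that something is new, unique, unknown or untested is made for them only; others in the source may bear on it.

- compound 1 `COc1cc2c(Nc3ccc(F)c(Cl)c3)ncnc2cc1OCCCn1ccnc1[N+](=O)[O-]` gives 2060 nM
- compound 2 `C#Cc1cccc(Nc2ncnc3cc(OCCOCCn4ccnc4[N+](=O)[O-])c(OC)cc23)c1` gives 6040 nM
- compound 3 `COc1cc2c(Nc3ccc(OCc4cccc(F)c4)c(Cl)c3)ncnc2cc1OCCCn1ccnc1[N+](=O)[O-]` gives 940 nM

All three numbers come from a functional assay on HT-29 cells (Homo sapiens) for inhibition, read by sulforhodamine B assay, with a stated time of 72 h (on this read-out higher numbers stand for weaker inhibition and lower numbers for stronger inhibition), and compound 3, at 940 nM here, has the lowest of them. The next compound is compound 4 `COc1cc2c(Nc3ccc(OCc4cccc(F)c4)c(Cl)c3)ncnc2cc1OCCOCCn1ccnc1[N+](=O)[O-]`, which keeps all of compound 3 except part of the chain that carries the nitroimidazole. The change is 2-(2-nitro-1H-imidazol-1-yl)ethoxy in place of (2-nitro-1H-imidazol-1-yl)methyl on a saturated chain carbon, two bonds along the chain from an oxygen on an aromatic ring and it sits on a saturated chain carbon, two bonds along the chain from an oxygen on an aromatic ring.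

Going by the values given here, only one single-change step has been measured, a 2.2-fold lower number from compound 1 to compound 3 (0.34 log units; beyond the scatter), and it lies at a different place, so it says nothing direct about this chain. The nearest hint is compound 2, which carries the 2-(2-nitro-1H-imidazol-1-yl)ethoxy ending of compound 4. Compound 2 stands at 6040 nM and, with the chain of compound 3, compound 1 stands at 2060 nM in the same assay. Those two compounds also differ in a second place, so the gap cannot be credited to the chain alone. The step expected in this assay is a 1.9-fold higher number from compound 3 to compound 4 (0.28 log units; within the scatter), towards weaker inhibition. For compound 4 the estimated value is 1800 nM with an expected range of 700 nM to 4500 nM.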

Compound 4, half-maximal inhibitory concentration: 2590 nM
The estimate for compound 4 lay 1.4-fold (0.16 log units) below the measured number, and the stated range covers the measured number.
By their numbers in this assay, from the lowest: compound 3; then compounds 1 and 4 (each within the scatter of the next); then compound 2.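

In this assay, putting 2-(2-nitro-1H-imidazol-1-yl)ethoxy in place of (2-nitro-1H-imidazol-1-yl)methyl gives a 2.8-fold higher number from compound 3 to compound 4 (0.44 log units; beyond the scatter) and so points towards weaker inhibition. Going by these compounds alone, this is the first measured step in which the chain carrying the nitroimidazole changes while the rest of the molecule stays the same; the earlier single-change step, a 2.2-fold lower number from compound 1 to compound 3 (0.34 log units; beyond the scatter), concerned the fluoro group and could not speak to this chain. The new step shows that this position is not indifferent to the change in this pair, although nothing available explains the shift in the number.

On these data alone, it remains open whether the same chain change would shift the number by a similar amount on the core of compound 1, as this step rests on one pair of compounds. The compounds shown also leave open how this read-out would respond to an amine in place of the nitroimidazole, or to an all-carbon chain longer than the one in compound 3.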